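A few compounds are considered here, and "the series" means these few. Any claim that something is new, unique, unknown or untested is made for them only; others in the source may bear on it.

Measured compounds:
compound 1, `COc1cc(N2C(N)=C(C#N)C(c3ccc([N+](=O)[O-])cc3)C3=C2CC(C)(C)CC3=O)cc(OC)c1OC`: 70%
compound 2, `COc1cc(N2C(N)=C(C#N)C(c3cccs3)C3=C2CC(C)(C)CC3=O)cc(OC)c1OC`: 15%

In a functional assay on Ehrlich cells (Mus musculus) for cytotoxicity, tested at 50 ug/mL (on this read-out higher numbers stand for a stronger effect at the one concentration tested and lower numbers for a weaker effect), compound 1 gives 70%, and compound 2 gives 15%, the lowest of the two numbers measured in this assay. The unmeasured compound 3, `COc1cc(N2C(N)=C(C#N)C(c3ccccc3)C3=C2CC(C)(C)CC3=O)cc(OC)c1OC`, differs from compound 2 in one place: phenyl in place of thiophen-2-yl on a saturated ring carbon. Going by the values given here, one measured step touches this same place: a number 55 percentage points lower from compound 1 to compound 2 (beyond the scatter). That step replaced a six-membered aromatic carbon ring, carrying a nitro group, with thiophen-2-yl and cost a large amount of activity. Compound 3 reverses part of that change, bringing back a six-membered aromatic carbon ring without the nitro group. Compound 3 is therefore expected to recover some activity, estimated at 40%, within 15% to 70%, a step of a number 25 percentage points higher from compound 2 to compound 3 (beyond the scatter). Among the compounds with values here, with only one step to lean on, and no measured case of phenyl at this place, the range is kept wide.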

Compound 3, a percentage reported as activity, at one concentration (the size of the read-out at that concentration, not a potency): 8%
Compound 3: middle estimate off by 32 percentage points, on the high side; the whole stated range lies above it.
By their numbers in this assay, from the lowest: compounds 3 and 2 (each within the scatter of the next); then compound 1.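

Placing phenyl instead of thiophen-2-yl on this saturated ring carbon gives a number 7 percentage points lower from compound 2 to compound 3 (within the scatter) in this assay and so does not separate the two unsubstituted rings, while removing only the nitro group gives a number 62 percentage points lower from compound 1 to compound 3 (beyond the scatter) and shows that the loss follows the nitro group, not the ring type. Among these compounds, strong activity at this position appears only with 4-nitrophenyl, the group carried by compound 1 . Nothing measured here explains why the nitro group makes this difference.

On these data alone, it remains open whether an amine, a carboxylic acid or a chlorine atom on the phenyl ring could stand in for the nitro group. As far as these compounds go, it is also open whether a nitro group on thiophen-2-yl would restore activity.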